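Ring size of the amine substituent on the aromatic nitrogen

The source may report more compounds than this note shows. Statements on the series, on what has been measured and on what is new or still open speak of the compounds shown alone.

Two compounds share one core and differ in the ring attached to the sulfonyl sulfur. Compound 1 `O=S(=O)(c1ccc(F)cc1)c1cn(C2CCNC2)c2ncccc12` gives 8.5 nM in an assay on HeLa cells for displacement of a labelled ligand from 5-hydroxytryptamine receptor 6 (Homo sapiens); on this read-out higher numbers stand for weaker inhibition and lower numbers for stronger inhibition. Among the compounds with values here, compound 2 `O=S(=O)(c1cccc(Br)c1)c1cn(C2CCNC2)c2ncccc12` gives 1.3 nM in this assay, and the step of a 6.5-fold lower number from compound 1 to compound 2 (0.82 log units; beyond the scatter) puts compound 2 at the lowest number of the two measured so far. Compound 3 `O=S(=O)(c1cccc(Br)c1)c1cn(C2CCCNC2)c2ncccc12` keeps the 3-bromophenyl of compound 2 and changes only the group on the aromatic nitrogen: piperidin-3-yl in place of pyrrolidin-3-yl on an aromatic nitrogen. Within the data shown here, no measured step touches this position; the single known step concerns the sulfonyl substituent alone, so it gives no guide to the present change. With nothing to go on, the expectation for compound 3 is a number near that of compound 2, and the expected step is a 1.9-fold higher number from compound 2 to compound 3 (0.28 log units; within the scatter). Compound 3 is therefore estimated at 2.5 nM in this assay, with a range from 0.7 nM to 10 nM.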

Compound 3, inhibition constant: 3.8 nM
The estimate for compound 3 lay 1.5-fold (0.18 log units) below the measured number, and the stated range covers the measured number.
By their numbers in this assay, from the lowest: compound 2; then compound 3; then compound 1.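

Within the data shown here, the group on the aromatic nitrogen can now be judged for the first time. In this assay with the 3-bromophenyl held fixed, piperidin-3-yl in place of pyrrolidin-3-yl gives a 2.9-fold higher number from compound 2 to compound 3 (0.47 log units; beyond the scatter) and so separates the two rings by a modest step beyond the usual scatter, with pyrrolidin-3-yl giving the stronger inhibition. Nothing measured here explains why the six-membered ring gives the higher number.

An azetidine ring or an open aminoethyl chain in place of pyrrolidin-3-yl would show whether the number keeps rising or falling as this group changes shape, and the present pair cannot predict either. Going by these compounds, it also remains open whether the step between these two rings would be the same with 4-fluorophenyl on the sulfonyl sulfur.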